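The source may report more compounds than this note shows. Statements on the series, on what has been measured and on what is new or still open speak of the compounds shown alone.

Measured so far in a functional assay on HCC827 cells (Homo sapiens) for antiproliferative activity, read by MTT assay, with a stated time of 72 h; a lower number here means a stronger inhibitor, a higher number a weaker inhibitor:
compound 1 `CN1CCN(c2ccc(Nc3ncc4nc(Nc5ccc(F)cc5)n([C@H]5CCCN(C(=O)CO)C5)c4n3)cc2)CC1` gives 1.8 nM
compound 2 `CN1CCN(c2ccc(Nc3ncc4nc(Nc5ccccc5)n([C@H]5CCN(C(=O)OC(C)(C)C)C5)c4n3)cc2)CC1` gives 110 nM

Compound 1 holds the lower of the two numbers in this assay, and compound 2 stands well apart from it, beyond the scatter; since compound 2 differs from compound 1 in more than one place, the two values show only that the series spans a wide window, not which change carries it.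

The step to compound 3 `CC(=O)Nc1cccc(-n2c(Nc3ccc(F)cc3)nc3cnc(Nc4ccc(N5CCN(C)CC5)cc4)nc32)c1` is a single exchange: 3-acetamidophenyl in place of 1-((hydroxymethyl)carbonyl)piperidin-3-yl on an aromatic nitrogen. The shared core, the (4-fluorophenyl)amino group and the methylpiperazinylphenylamino arm are kept. Going by the values given here, no measured pair isolates this exchange, so its size has to be judged from the structural change alone. The group that enters is of the same count of heavy atoms and keeps one hydrogen-bond donor, but it is aromatic where the group that leaves is not, and the defined stereocentre is lost. An expectation of a modest weakening, beyond the scatter but well short of the gap to compound 2, seems reasonable.

Compound 3 is therefore expected to give 8 nM in this assay, within 2 nM to 40 nM, a step of a 4.4-fold higher number from compound 1 to compound 3 (0.65 log units; beyond the scatter) that is an estimate only.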

Compound 3, half-maximal inhibitory concentration: 10 nM
Compound 3: the middle estimate sits 1.3-fold (0.10 log units) below what was measured; the range from low to high includes it.
By their numbers in this assay, from the lowest: compound 1; then compound 3; then compound 2.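

Going by these compounds alone, the exchange of 1-((hydroxymethyl)carbonyl)piperidin-3-yl for 3-acetamidophenyl on the aromatic nitrogen gives the first single-place comparison: in this assay, the result is a 5.6-fold higher number from compound 1 to compound 3 (0.74 log units; beyond the scatter), a modest step beyond the scatter. Compound 3 has a six-membered aromatic ring of carbon only at this place and no defined stereocentre, yet still gives 10 nM, so neither the non-aromatic ring nor the defined stereocentre of compound 1 is essential for activity at this level, although the step shows that the exchange is not neutral. No available evidence accounts for the size of this step, and the exchange alters the ring and its substituent together, so the pair cannot assign the step to either one.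

The compounds shown leave open how much of the step belongs to the ring and how much to its substituent, a question that plain phenyl or 3-aminophenyl on the same nitrogen would address. Also open, from the compounds shown here alone, is how a carboxylic acid in place of the acetamido group would read with the (4-fluorophenyl)amino group and the rest of compound 3 unchanged.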